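A Pyridinyl Sulfonamide Weighed Against Its Chlorophenyl Parent

A few compounds are considered here, and "the series" means these few. Any claim that something is new, unique, unknown or untested is made for them only; others in the source may bear on it.

Compound 1 `O=C(NCc1ccc(CNS(=O)(=O)c2cccc(C(F)(F)F)c2)cc1)c1ccc(F)cc1`: 100 nM
Compound 2 `O=C(NCc1ccc(CNS(=O)(=O)c2ccc([N+](=O)[O-])cc2)cc1)c1ccc(F)cc1`: 1000 nM
Compound 3 `O=C(NCc1ccc(CNS(=O)(=O)c2ccc(Cl)cc2)cc1)c1ccc(F)cc1`: 100 nM

In an assay on MDA-MB-231 cells for binding affinity to C-X-C chemokine receptor type 4 (Homo sapiens), read by fluorescence and microscopy, with stated times of 10 min and 30 min (on this read-out lower numbers stand for an effect already at smaller amounts and higher numbers for an effect only at larger amounts of compound), compound 3 gives 100 nM and stands level with compound 1, the two sharing the lowest number of the three, while a 10-fold lower number from compound 2 to compound 3 (1.00 log units; beyond the scatter) and no change at the digits printed from compound 1 to compound 3 (within the scatter) frame its position. Compound 4 `O=C(NCc1ccc(CNS(=O)(=O)c2cccnc2)cc1)c1ccc(F)cc1` carries pyridin-3-yl in place of 4-chlorophenyl on a sulfonyl sulfur. Going by the values given here, the measured steps swap substituents on a phenyl ring; none replaces the ring itself with a ring holding a hetero atom, so no direct precedent exists. Since chloro and trifluoromethyl gave the same number and only nitro cost affinity, a small loss for compound 4 is expected, a 2.0-fold higher number from compound 3 to compound 4 (0.30 log units; within the scatter). Compound 4 is therefore estimated at 200 nM, within 50 nM to 1000 nM.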

Compound 4, effective concentration (reported as EC, without a stated level of effect): 1000 nM
For compound 4 the middle estimate is 5.0-fold (0.70 log units) below the measured one; low and high end bracket the measured number.
By their numbers in this assay, from the lowest: compounds 1 and 3 (each within the scatter of the next); then compounds 2 and 4 (each within the scatter of the next).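

In this assay, putting pyridin-3-yl on the sulfonyl sulfur gives a 10-fold higher number from compound 3 to compound 4 (1.00 log units; beyond the scatter) and a 10-fold higher number from compound 1 to compound 4 (1.00 log units; beyond the scatter), but no change at the digits printed from compound 2 to compound 4 (within the scatter). This position therefore responds to replacing the carbon-only ring itself, not only to changing substituents on a phenyl ring, and compound 4 falls level with compound 2 rather than with compounds 1 and 3. No supporting data bear on this loss, so it remains unexplained.

The compounds shown leave open whether pyridin-4-yl would match compound 4 or compound 3. They also leave open whether a chloro group on the pyridine ring would restore the number of compound 3.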